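The source may hold more compounds than are shown below. What is called first, only, known or untested is meant among the compounds shown, and "the series" means these compounds.

In an ADME assay on Akata cells (Homo sapiens) for cytotoxicity, with a stated time of 7 days (on this read-out higher numbers stand for lower toxicity in this test and lower numbers for higher toxicity in this test), three compounds that share one core have been read, and none of them gives a number. Compound 1 (`CC(C)CSc1nc(N)nc2c1ncn2/C=C1/CC1(CO)CO`) reads > 20000 nM, which is a limit and not a number. Compound 2 (`COCCOc1nc(N)nc2c1ncn2/C=C1/CC1(CO)CO`) reads > 20000 nM, again a limit. Compound 3 (`CCCSc1nc(N)nc2c1ncn2/C=C1/CC1(CO)CO`) reads > 20000 nM, also a limit, so it has no measured place of its own. All the evidence so far comes down to the limit of > 20000 nM in this assay, at which 3 of the 3 values shown sit.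

Compound 4 (`Nc1nc(NCc2ccccc2)c2ncn(/C=C3/CC3(CO)CO)c2n1`) carries benzylamino in place of propylsulfanyl on an aromatic carbon. Among the compounds with values here, three measured steps bear on this change. Two exchange the group on an aromatic carbon, a step that the two limits leave unreadable from compound 1 to compound 2 and a step that the two limits leave unreadable from compound 2 to compound 3, and one shortens the chain, a step that the two limits leave unreadable from compound 1 to compound 3. None of them has a readable size, and none gives a direction. Given a step that the two limits leave unreadable from compound 2 to compound 3, the expected change is nothing beyond the scatter, and the step is estimated as a number no higher from compound 3 to compound 4 (the limit leaves the size open). Compound 4 is expected at 20000 nM, with an estimated range of 10000 nM to 40000 nM, and the assay will most likely report only a limit again.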

Compound 4, half-maximal cytotoxic concentration: > 24000 nM
Compound 4 ended at the assay's limit (the forecaster's own chance of this, stated with the estimate: 80%); middle value at least 1.2-fold (0.07 log units) away from the limit.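

In this assay compound 4 gives > 24000 nM, a limit and not a number. Every step joining compound 1, compound 2 or compound 3 to compound 4 links two limits, and none can be read. The compounds shown leave open whether exchanging the group on that aromatic carbon changes the read-out at all.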